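Working notes: replacing 2-chlorophenyl with pyridin-3-yl

The source may hold more compounds than are shown below. What is called first, only, known or untested is meant among the compounds shown, and "the series" means these compounds.

Measured in a functional assay on HepG2 cells (Homo sapiens) for cytotoxicity, read by MTT assay, with a stated time of 48 h; a lower number here means a stronger inhibitor, a higher number a weaker inhibitor

- compound 1 `Cc1ccccc1-c1nnc(SCCn2c([N+](=O)[O-])cnc2C)o1` at 5100 nM
- compound 2 `Cc1ncc([N+](=O)[O-])n1CCSc1nnc(-c2ccccc2F)o1` at 3700 nM
- compound 3 `Cc1ncc([N+](=O)[O-])n1CCSc1nnc(-c2ccccc2Cl)o1` at 15600 nM

Compound 3 holds the highest of the three numbers, with compound 1 nearest and compound 2 furthest. The next entry is compound 4 `Cc1ncc([N+](=O)[O-])n1CCSc1nnc(-c2cccnc2)o1`, not yet measured. Its change from compound 3 is pyridin-3-yl in place of 2-chlorophenyl on an aromatic carbon and it removes the chloro group.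

Two measured steps bring that chloro group in, and both are modest and beyond the scatter: a 3.1-fold higher number from compound 1 to compound 3 (0.49 log units; beyond the scatter) (chloro in place of methyl) and a 4.2-fold higher number from compound 2 to compound 3 (0.62 log units; beyond the scatter) (chloro in place of fluoro). The third, a 1.4-fold lower number from compound 1 to compound 2 (0.14 log units; within the scatter) (fluoro in place of methyl), stays within the scatter. Neither compound without chloro carries a number as high as that of compound 3. Among the compounds with values here, no measured step introduces pyridin-3-yl, however, so these steps guide the expectation only loosely.

A modest step toward a lower number is therefore expected in this assay on leaving compound 3. The estimated change is a 2.2-fold lower number from compound 3 to compound 4 (0.35 log units; beyond the scatter) (an expectation only). Compound 4 is estimated at 7000 nM (expected range 2500 nM to 20000 nM).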

Compound 4, half-maximal inhibitory concentration: 9600 nM
Estimate against measurement, compound 4: 1.4-fold (0.14 log units) below; the measured number falls inside the stated range.
By their numbers in this assay, from the lowest: compounds 2, 1, 4 and 3 (each within the scatter of the next, the first and the last beyond it).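

In this assay pyridin-3-yl, the first ring with a hetero atom at this position on the shared core, stays within the scatter of both 2-chlorophenyl (a 1.6-fold lower number from compound 3 to compound 4 (0.21 log units; within the scatter)) and 2-methylphenyl (a 1.9-fold higher number from compound 1 to compound 4 (0.27 log units; within the scatter)). Only the comparison with 2-fluorophenyl gives a modest step beyond the scatter (a 2.6-fold higher number from compound 2 to compound 4 (0.41 log units; beyond the scatter)), so among these four compounds a carbon-only ring is not required at this position for a number in the range of compound 1 and compound 3. No measurement available here accounts for these differences.

The change from compound 3 to compound 4 removes the chloro group and brings in the ring nitrogen together, so unsubstituted phenyl would be needed to separate the two, and pyridin-4-yl would show whether the place of the ring nitrogen matters. Going by these compounds, all four groups at this position are six-membered aromatic rings, so it remains open how the series responds to a non-aromatic morpholin-4-yl group, or to a phenyl ring bearing an amine or a carboxylic acid.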